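From 3-chlorobenzyl to 4-chlorobenzyl

This account rests on a few compounds, and the source may have more. Where it says the series, first, only, none or still open, it means among the compounds named here.

Measured so far in a functional assay on the whole organism with Rattus norvegicus as the target (on this read-out lower numbers stand for an effect already at smaller amounts and higher numbers for an effect only at larger amounts of compound), for three compounds
- compound 1 `CCN(CCNC(=O)c1cc(Cl)c(N)cc1OC)Cc1cccc(OC)c1` gives 1 mg/kg
- compound 2 `CCN(CCNC(=O)c1cc(Cl)c(N)cc1OC)Cc1ccc(OC)cc1` gives 0.2 mg/kg
- compound 3 `CCN(CCNC(=O)c1cc(Cl)c(N)cc1OC)Cc1cccc(Cl)c1` gives 0.58 mg/kg

Compound 3 stands level with one of the other two compounds and clear of the second. The smaller gap is a 1.7-fold lower number from compound 1 to compound 3 (0.24 log units; within the scatter) and the wider one is a 2.9-fold higher number from compound 2 to compound 3 (0.46 log units; beyond the scatter).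

The next compound is compound 4 `CCN(CCNC(=O)c1cc(Cl)c(N)cc1OC)Cc1ccc(Cl)cc1`, which carries 4-chlorophenyl in place of 3-chlorophenyl on a saturated chain carbon bound to an amine nitrogen.

Within the data shown here, the closest precedent has the same form, with 4-methoxyphenyl in place of 3-methoxyphenyl, and it gave a 5.0-fold lower number from compound 1 to compound 2 (0.70 log units; beyond the scatter). Among the measured compounds shown here, that single modest step is the only evidence, and no measured pair shows the same change with chloro. A move in the same direction is therefore expected in this assay, though probably a smaller one. The estimated step is a 2.3-fold lower number from compound 3 to compound 4 (0.37 log units; beyond the scatter). Compound 4 is expected at 0.25 mg/kg, within an estimated range of 0.09 mg/kg to 0.6 mg/kg.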

Compound 4, dose for half-maximal effect: 0.24 mg/kg
Estimate against measurement, compound 4: 1.0-fold (0.02 log units) above; the measured number falls inside the stated range.
By their numbers in this assay, from the lowest: compounds 2 and 4 (each within the scatter of the next); then compounds 3 and 1 (each within the scatter of the next).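

In this assay, 4-chlorophenyl in place of 3-chlorophenyl on a saturated chain carbon bound to an amine nitrogen gives a 2.4-fold lower number from compound 3 to compound 4 (0.38 log units; beyond the scatter), so the step seen earlier with the methoxyphenyl pair recurs with a second substituent. Compound 4 stands clear of the 3-methoxyphenyl compound, with a 4.2-fold lower number from compound 1 to compound 4 (0.62 log units; beyond the scatter), while a 1.2-fold higher number from compound 2 to compound 4 (0.08 log units; within the scatter) leaves it level with the 4-methoxyphenyl compound. Chloro in place of methoxy thus moves the number little with either placement: the same change on two cores in this assay, a 1.7-fold lower number (0.24 log units; within the scatter) from compound 1 to compound 3 and a 1.2-fold higher number (0.08 log units; within the scatter) from compound 2 to compound 4, 2.1-fold (0.32 log units) apart, within the scatter of two such steps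

From the compounds shown here alone, whether 4-phenyl substitution keeps this advantage with a nitrile, a trifluoromethyl or a hydroxyl in place of chloro and methoxy stays open. The compounds shown also leave open how a plain phenyl without any substituent compares with these four.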